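Carboxy in place of cyano on the outer ring

The compounds below may be only part of what the source reports. "The series", "measured", "known", "first", "only" and "open" are said of these compounds alone.

Of the compounds shown here, three built on one shared core have been measured in an assay on isolated protein for inhibition of 2-Hydroxyacid oxidase 2 (Rattus norvegicus); on this read-out lower numbers stand for stronger inhibition and higher numbers for weaker inhibition. Compound 2 `Cc1n[nH]c(C(=O)O)c1Cc1cccc(-c2ccc(C#N)cc2)c1` gives 300 nM. Compound 3 `Cc1n[nH]c(C(=O)O)c1Cc1cccc(C(F)(F)F)c1` gives 300 nM, and compound 1 `Cc1n[nH]c(C(=O)O)c1Cc1cccc(-c2cccc(F)c2)c1` gives 500 nM. Compound 2 and compound 3 stand level and together hold the lowest numbers of the three; the step of no change at the digits printed from compound 2 to compound 3 (within the scatter) and the step of a 1.7-fold lower number from compound 1 to compound 2 (0.22 log units; within the scatter) both stay inside the scatter, as does a 1.7-fold lower number from compound 1 to compound 3 (0.22 log units; within the scatter), so none of the three can be called stronger than another on these numbers.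

Compound 4 `Cc1n[nH]c(C(=O)O)c1Cc1cccc(-c2ccc(C(=O)O)cc2)c1` has not yet been measured. It differs from compound 2 by carboxy in place of cyano on an aromatic carbon. For the measured compounds named here, no measured step swaps exactly these two groups. The nearest comparisons are a 1.7-fold lower number from compound 1 to compound 2 (0.22 log units; within the scatter), which altered the outer ring, and no change at the digits printed from compound 2 to compound 3 (within the scatter), which removed that outer ring altogether; neither moved the number beyond the scatter. On that basis the expected step of no change at the digits printed from compound 2 to compound 4 (within the scatter) is small, with no direction that should stand out from the scatter. For compound 4 the estimate in this assay is 300 nM, with a range from 100 nM to 1000 nM.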

Compound 4, half-maximal inhibitory concentration: 1100 nM
Compound 4: middle estimate off by 3.7-fold (0.56 log units), on the low side, and the stated range ends below it.
By their numbers in this assay, from the lowest: compounds 2, 3 and 1 (each within the scatter of the next); then compound 4.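

In this assay, for the compounds shown here, exchanging cyano for carboxy on the outer ring, para to a large group, gives a 3.7-fold higher number from compound 2 to compound 4 (0.56 log units; beyond the scatter), and this is the first step in the set that lies beyond the scatter. The earlier changes at this part of the molecule were larger on paper, since they replaced one substituted outer ring with another or removed that ring in favour of trifluoromethyl, yet they all stayed within the scatter, so this position turns out not to be indifferent to the group placed on it: a swap of one small group for another is enough to give a weaker result. Nothing in the available data explains why the number rose.

Going by these compounds alone, with only one carboxy compound at hand, it remains open whether this weakening belongs to carboxy itself or would also appear with related groups at the same place, such as a methyl ester, a primary amide or a hydroxy group. On these data alone, it is also open whether carboxy would give the same result at another position on the outer ring.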